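The compounds below may be only part of what the source reports. "The series", "measured", "known", "first", "only" and "open" are said of these compounds alone.

Compound 1 `NC1=NC2(CCSCC2)N(OCCCOc2cccc(Cl)c2)C(N)=N1` gives 60 nM in a functional assay on A549 cells (Homo sapiens) for antiproliferative activity, read by MTT assay, with a stated time of 72 h (on this read-out higher numbers stand for weaker inhibition and lower numbers for stronger inhibition), the lowest of the three numbers available; compound 2 `NC1=NC2(CCOCC2)N(OCCCOc2cccc(Cl)c2)C(N)=N1` gives 150 nM and compound 3 `NC1=NC2(CCOCC2)N(OCCCOc2ccc(Br)cc2)C(N)=N1` gives 280 nM, and both gaps from compound 1 lie beyond the scatter. Compound 4 `NC1=NC2(CCSCC2)N(OCCCOc2ccccc2Br)C(N)=N1` differs from compound 1 in one place: 2-bromophenyl in place of 3-chlorophenyl on an oxygen on a saturated carbon. Among the measured compounds shown here, the only measured step of a related kind is a 1.9-fold higher number from compound 2 to compound 3 (0.27 log units; within the scatter), in which a 3-chlorophenyl also leaves and a 4-bromophenyl enters on the core of compound 2; for a 2-bromophenyl there is no measured counterpart. On that basis only a small step, if any, is expected in this assay, leaning toward a somewhat higher number. Compound 4 is therefore estimated at 100 nM, with a range of 40 nM to 250 nM. That estimate means an expected step of a 1.7-fold higher number from compound 1 to compound 4 (0.22 log units; within the scatter).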

Compound 4, half-maximal inhibitory concentration: 40 nM
Compound 4: the middle estimate sits 2.5-fold (0.40 log units) above what was measured, within the range that was stated.
By their numbers in this assay, from the lowest: compounds 4 and 1 (each within the scatter of the next); then compounds 2 and 3 (each within the scatter of the next).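

In this assay, among the compounds shown here, 2-bromophenyl in place of 3-chlorophenyl gives a 1.5-fold lower number from compound 1 to compound 4 (0.18 log units; within the scatter), so this place on an oxygen on a saturated carbon accepts a group that had no measured counterpart without a step beyond the scatter. The halogen and its ring position change together here, and this single step cannot separate them. No evidence bears on why the two numbers lie so close. The compounds shown leave open how 2-bromophenyl reads on the core of compound 2. They also leave open whether a phenyl carrying an amine or a carboxylic acid instead of a halogen would fit here.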